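Butyl to 4-fluorobenzyl: cytotoxicity notes on compound 4

The source may hold more compounds than are shown below. What is called first, only, known or untested is meant among the compounds shown, and "the series" means these compounds.

Measured in an ADME assay on Vero cells (Chlorocebus sabaeus) for cytotoxicity; on this read-out higher numbers stand for lower toxicity in this test and lower numbers for higher toxicity in this test:
- compound 1 `CC(=O)c1c(N2CCCCC2)[nH]c2c(F)cc(F)cc2c1=O`: > 25000 nM (a limit)
- compound 2 `CCCCNc1[nH]c2c(F)cc(F)cc2c(=O)c1C(C)=O`: > 25000 nM (a limit)
- compound 3 `CC(=O)c1c(OCc2ccc(Cl)c(Cl)c2)[nH]c2c(F)cc(F)cc2c1=O`: > 25000 nM (a limit)

Compound 2 has no numerical value, only the limit > 25000 nM in this assay. The change to compound 4 `CC(=O)c1c(NCc2ccc(F)cc2)[nH]c2c(F)cc(F)cc2c1=O` is 4-fluorophenyl in place of propyl on a saturated chain carbon bound to a nitrogen on an aromatic ring, in words 4-fluorophenyl in place of propyl on a saturated chain carbon bound to a nitrogen on an aromatic ring. For the measured compounds named here, the one measured step is a step that the two limits leave unreadable from compound 1 to compound 2, and the wider evidence is the limit of > 25000 nM in this assay, at which 3 of the 3 values shown sit. From these, no step beyond the scatter is expected in this assay, in either direction. The expected step is a number no higher from compound 2 to compound 4 (the limit leaves the size open). For compound 4 the estimate is 25000 nM, with an expected range of 12000 nM to 40000 nM.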

Compound 4, half-maximal cytotoxic concentration: > 25000 nM
Compound 4: no number, only a limit; the forecaster's own chance of this, stated with the estimate: 80%; the middle value sits exactly at the limit.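

Compound 2 and compound 4 are both recorded only as limits in this assay, so no step can be read between them. The compounds shown leave open where any of them would give a numerical value, and whether any change in the series would shift it.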